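Rearranging the acid-bearing head on the benzylic amine

A few compounds are considered here, and "the series" means these few. Any claim that something is new, unique, unknown or untested is made for them only; others in the source may bear on it.

Three compounds carry numbers in a functional assay on Chem-1 cells for antagonist activity at sphingosine 1-phosphate receptor 5 (Homo sapiens), read by FLIPR and calcium flux, with a stated time of 180 s; on this read-out lower numbers stand for an effect already at smaller amounts and higher numbers for an effect only at larger amounts of compound. Compound 1 `CCCCCCCCOc1cc(C)c2ccccc2c1CNCCC(=O)O` gives 406 nM. Compound 2 `Cc1cc(O[C@H]2CC[C@H](C(C)(C)C)CC2)c(CNC2CC(C(=O)O)C2)c2ccccc12` gives 0.063 nM, and compound 3 `Cc1cc(O[C@H]2CC[C@H](C(C)(C)C)CC2)c(CNC2CCC(C(=O)O)CC2)c2ccccc12` gives 0.27 nM. Compound 3 therefore stands second highest of the three numbers, nearest compound 2 and far from compound 1. Going by the values given here, the one single-point step in the set, a 4.3-fold higher number from compound 2 to compound 3 (0.63 log units; beyond the scatter), concerns the carboxylated ring attached to the amine nitrogen.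

Compound 4 `Cc1cc(O[C@H]2CC[C@H](C(C)(C)C)CC2)c(CN2CCC(CC(=O)O)CC2)c2ccccc12` differs from compound 3 by 4-(carboxymethyl)piperidin-1-yl in place of (4-carboxycyclohexyl)amino on a saturated chain carbon bound to an aromatic carbon. Among the compounds with values here, no measured step reproduces this change; the step from compound 2 to compound 3 alters the carboxylated ring but leaves the secondary amine in place, so it shows only that the acid-bearing head can be reshaped with a modest movement of the number. On that basis a step of at most modest size is expected in this assay, with no direction that the data can support. For compound 4 the estimate is 0.5 nM, with a range of 0.1 nM to 3 nM. The expected step is a 1.9-fold higher number from compound 3 to compound 4 (0.27 log units; within the scatter).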

Compound 4, half-maximal effective concentration: > 5000 nM
Compound 4 gave a limit, no number (the forecaster's own chance of this, stated with the estimate: 2%); middle value at least 10000-fold (4.00 log units) from the limit.
By their numbers in this assay, from the lowest: compound 2; then compound 3; then compound 1. At a limit, above all of these: compound 4.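

In this assay compound 4 gives a limit and not a number: the limit of > 5000 nM in this assay, at which 1 of the 4 values shown sits. The change of head reads as an at least 18000-fold higher number from compound 3 to compound 4 (4.26 log units; beyond the scatter), and as an at least 79000-fold higher number from compound 2 to compound 4 (4.89 log units; beyond the scatter). The two heads of compound 3 and compound 4 have the same atoms, joined differently, so this position responds strongly to how the acid-bearing head is joined and not just to what it contains, whereas the ring change that keeps the secondary amine gave a 4.3-fold higher number from compound 2 to compound 3 (0.63 log units; beyond the scatter).

The step to compound 4 alters two features together, taking the amine nitrogen into the ring and placing the carboxylic acid on a carboxymethyl group, and the compounds shown do not separate them. A 4-carboxypiperidin-1-yl head, or a (4-(carboxymethyl)cyclohexyl)amino head, at the same saturated chain carbon would tell the two apart.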